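One Group Swapped Between Two Assay Limits

A few compounds are considered here, and "the series" means these few. Any claim that something is new, unique, unknown or untested is made for them only; others in the source may bear on it.

Compound 1 `COC(=O)c1cc(C2=C(c3cc(OC)c(OC)c(OC)c3)C(=O)CC2O[SiH2]C(C)(C)C)ccc1OC`: > 100 ug/mL (a limit)
Compound 2 `COc1ccc(C2=C(c3cc(OC)c(OC)c(OC)c3)C(=O)CC2O)cc1O`: < 1 ug/mL (a limit)

Both results come from an ADME assay on PA-1 cells (Homo sapiens) for cytotoxicity, read by MTT assay, with a stated time of 72 h; a higher number here means a weaker inhibitor, a lower number a stronger inhibitor. Neither is an exact number. Compound 1 stands at the limit of > 100 ug/mL in this assay, at which 1 of the 2 values shown sits, the weak end of the two results. Compound 2 stands at the strong end, at the limit of < 1 ug/mL in this assay, at which 1 of the 2 values shown sits.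

Compound 3 `COCOc1cc(C2=C(c3cc(OC)c(OC)c(OC)c3)C(=O)CC2O[SiH2]C(C)(C)C)ccc1OC` has not yet been measured. It keeps the core of compound 1 and changes a single group: methoxymethoxy in place of methoxycarbonyl on an aromatic carbon. Methoxymethoxy takes the place of methoxycarbonyl on an aromatic carbon, ortho to a methoxy group.

Within the data shown here, no measured pair shows what this swap does, so any forecast is a judgement. Compound 2 gives < 1 ug/mL, a limit, which shows that strong inhibition does occur among these compounds. A moderate move toward stronger inhibition is therefore expected in this assay, although another result at a limit remains possible. The expected step is an at least 2.5-fold lower number from compound 1 to compound 3 (0.39 log units; beyond the scatter). For compound 3 the estimated value is 40 ug/mL, with an expected range from 6 ug/mL to 120 ug/mL.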

Compound 3, half-maximal inhibitory concentration: 13.5 ug/mL
Beside the measured number, compound 3's estimate is 3.0-fold (0.47 log units) above it; measured number inside the range.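

In this assay compound 1 gives > 100 ug/mL, which is a limit of the assay and not an exact number. Putting methoxymethoxy in place of methoxycarbonyl on this aromatic carbon, ortho to a methoxy group, gives an at least 7.4-fold lower number from compound 1 to compound 3 (0.86 log units; beyond the scatter), so the first measured pair shows that the result responds to a change at this one place, even though the leaving and entering groups have the same heavy-atom count and the same count of hydrogen-bond acceptors. The true size of the step has no upper bound, because the number for compound 1 is not exact: the limit of > 100 ug/mL in this assay, at which 1 of the 3 values shown sits.

What the pair cannot tell is which feature of the two groups matters, since a single swap cannot separate them, and other groups at this position, such as a carboxylic acid, an amine or a longer chain like ethoxy, would be needed to show whether the result follows any trend. Compound 2 differs from compound 3 in more than one place, so its limit cannot show how much of its stronger result comes from this position and how much from the other change.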